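Trifluoromethyl pyrazole analogue of compound 3

The source may report more compounds than this note shows. Statements on the series, on what has been measured and on what is new or still open speak of the compounds shown alone.

Among the three compounds measured in an assay on isolated protein for inhibition of Leucine-rich repeat serine/threonine-protein kinase 2 (Homo sapiens), read by TR-FRET and LanthaScreen, with stated times of 50 min and 30 min, in the presence of a further agent that is not named here (a higher number here means a weaker inhibitor, a lower number a stronger inhibitor), compound 3 `Cc1n[nH]cc1Nc1nc(N)c2c(C#N)c(N3CCC[C@H]3C)n(C)c2n1` gives 42 nM, the highest number of the set. Compound 2 `C[C@@H]1CCCN1c1c(C#N)c2c(N)nc(Nc3cn(C)nc3Cl)nc2n1C` gives 34 nM, and the step of a 1.2-fold higher number from compound 2 to compound 3 (0.09 log units; within the scatter) lies within the scatter. Compound 1 `C[C@@H]1CCCN1c1c(C#N)c2c(N)nc(Nc3cn[nH]c3)nc2n1C` gives 6 nM, the lowest number, and compound 3 is separated from it by a 7.0-fold higher number from compound 1 to compound 3 (0.85 log units; beyond the scatter).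

Compound 4 `C[C@@H]1CCCN1c1c(C#N)c2c(N)nc(Nc3cn(C)nc3C(F)(F)F)nc2n1C` differs from compound 3 in one place: 1-methyl-3-(trifluoromethyl)-1H-pyrazol-4-yl in place of 3-methyl-1H-pyrazol-4-yl on a nitrogen on an aromatic ring. Among the compounds with values here, two measured steps bear on this. The step of a 5.7-fold higher number from compound 1 to compound 2 (0.75 log units; beyond the scatter) shows what happens when the pyrazole carries both a methyl on its nitrogen and a chloro on its carbon. The step of a 7.0-fold higher number from compound 1 to compound 3 (0.85 log units; beyond the scatter) shows the effect of a methyl alone on the pyrazole carbon. Compound 2 and compound 3 sit within the scatter of each other, so replacing the methyl by a chloro together with methylation of the pyrazole nitrogen made no difference that could be resolved. Within the data shown here, compound 4 carries a trifluoromethyl in place of that chloro, which no measured pair covers directly.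

Compound 4 is therefore expected to give a number close to that of compound 3, with a step of about a 1.3-fold higher number from compound 3 to compound 4 (0.12 log units; within the scatter). The estimate for compound 4 is 55 nM, within a range from 20 nM to 160 nM.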

Compound 4, half-maximal inhibitory concentration: 508 nM
Beside the measured number, compound 4's estimate is 9.2-fold (0.97 log units) below it; measured number above the stated range.
By their numbers in this assay, from the lowest: compound 1; then compounds 2 and 3 (each within the scatter of the next); then compound 4.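

In this assay, the group on an aromatic carbon of the pyrazole proves to matter far more than compounds 2 and 3 suggested: trifluoromethyl in place of chloro gives a 15-fold higher number from compound 2 to compound 4 (1.17 log units; beyond the scatter), so the closeness of compound 2 and compound 3 does not extend to this group. The full exchange of 3-methyl-1H-pyrazol-4-yl for 1-methyl-3-(trifluoromethyl)-1H-pyrazol-4-yl on a nitrogen on an aromatic ring gives a 12-fold higher number from compound 3 to compound 4 (1.08 log units; beyond the scatter), and measured from the unsubstituted pyrazole the loss reaches an 85-fold higher number from compound 1 to compound 4 (1.93 log units; beyond the scatter), a large step where the earlier changes at this ring were modest or within the scatter. Nothing among the data shown gives a measured reason for this loss.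

The compounds shown leave open whether the loss is tied to trifluoromethyl alone or would also appear with other groups on that aromatic carbon, such as an ethyl, a methoxy or an amine. They also leave open how a trifluoromethyl pyrazole would behave with a hydrogen on its ring nitrogen in place of the methyl carried by compound 4.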